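The source may hold more compounds than are shown below. What is called first, only, known or untested is meant among the compounds shown, and "the series" means these compounds.

Compound 2 `CC(C)(C)CNCCS(=O)(=O)NC(=O)c1ccc(Nc2nc(NC3(c4ccc(Cl)cc4)CC3)nc(OCC(F)(F)F)n2)cc1` is the lower of the two compounds measured in an ADME assay on microsomes from liver (Rattus norvegicus) for metabolic stability, with a stated time of 10 min (a lower number here means that less of the compound is left, a higher number that more of the compound is left), where compound 2 gives 90%. Its nearest neighbour, compound 1 `O=C(NS(=O)(=O)c1ccc(F)cc1)c1ccc(Nc2nc(NC3(c4ccc(Cl)cc4)CC3)nc(OCC(F)(F)F)n2)cc1`, gives 99% in this assay, and the step of a number 9 percentage points lower from compound 1 to compound 2 (within the scatter) lies within the scatter. Compound 3 `O=C(NS(=O)(=O)CCNCc1ccccc1)c1ccc(Nc2nc(NC3(c4ccc(Cl)cc4)CC3)nc(OCC(F)(F)F)n2)cc1` differs from compound 2 by phenyl in place of tert-butyl on a saturated chain carbon bound to an amine nitrogen. Going by the values given here, no measured step covers this change; the only step known, from compound 1 to compound 2, sits elsewhere on the molecule and is within the scatter. Compound 3 is therefore expected to remain near compound 2, with a number 10 percentage points lower from compound 2 to compound 3 (within the scatter) as the expected step. The estimate for compound 3 in this assay is 80%, ranging from 55% to 97%.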

Compound 3, percent of the compound remaining: 100%
For compound 3 the middle estimate is 20 percentage points below the measured one; the whole stated range lies below it.
By their numbers in this assay, from the lowest: compounds 2, 1 and 3 (each within the scatter of the next).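

In this assay, phenyl in place of tert-butyl on a saturated chain carbon bound to an amine nitrogen gives a number 10 percentage points higher from compound 2 to compound 3 (within the scatter), so this second position also shows no step beyond the scatter. 2-(Benzylamino)ethyl in place of 4-fluorophenyl on a sulfonyl sulfur gives a number 1 percentage points higher from compound 1 to compound 3 (within the scatter), so these two sulfonyl substituents also stay within the scatter. On these data alone, what a pyridyl or cyclohexyl ring would give at this place remains open, as does a carboxylic acid on the chain. No evidence is available to explain these results.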